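The compounds below may be only part of what the source reports. "The series", "measured", "known", "first", "only" and "open" are said of these compounds alone.

The measured compounds:
compound 1 `O=C(C1CCCCC1)N1CC(c2nc(-c3cccc(F)c3)no2)C1` — 1000 nM
compound 2 `Cc1cccc(S(=O)(=O)N2CC(c3nc(-c4cccc(Cl)c4)no3)C2)c1` — > 10000 nM
compound 3 `O=C(C1CCC(C(F)(F)F)CC1)N1CC(c2nc(-c3cccc(F)c3)no2)C1` — 680 nM

For the measured compounds named here, in an assay on HEK293 cells for positive allosteric modulation of metabotropic glutamate receptor 5 (Homo sapiens), read by FLIPR (on this read-out lower numbers stand for an effect already at smaller amounts and higher numbers for an effect only at larger amounts of compound), compound 3 gives one of only two numbers, and it lies close to compound 1: a 1.5-fold lower number from compound 1 to compound 3 (0.17 log units; within the scatter). The value of compound 2 is a limit of the assay (the limit of > 10000 nM in this assay, at which 1 of the 3 values shown sits). Compound 4 `Cc1cccc(-c2noc(C3CN(C(=O)C4CCC(C(F)(F)F)CC4)C3)n2)c1` differs from compound 3 in one place: methyl in place of fluoro on an aromatic carbon. Going by the values given here, no measured step concerns this change; the single measured step, a 1.5-fold lower number from compound 1 to compound 3 (0.17 log units; within the scatter), alters the saturated ring and bears only loosely on the aromatic ring. Compound 2 differs from compound 3 in several places, so its limit says nothing specific about this change. A step of no size beyond the scatter is therefore expected in this assay, with a 1.2-fold higher number from compound 3 to compound 4 (0.07 log units; within the scatter). Compound 4 is estimated at 800 nM, within a range from 300 nM to 2500 nM.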

Compound 4, half-maximal effective concentration: 1000 nM
The estimate for compound 4 lay 1.3-fold (0.10 log units) below the measured number, within the range that was stated.
By their numbers in this assay, from the lowest: compounds 3, 1 and 4 (each within the scatter of the next). At a limit, above all of these: compound 2.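

For the compounds shown here, the change on this aromatic carbon is the first one measured on that ring with the rest of the molecule held constant, and this assay shows a 1.5-fold higher number from compound 3 to compound 4 (0.17 log units; within the scatter) when 3-methylphenyl replaces 3-fluorophenyl. With the trifluoromethyl-bearing saturated ring kept, this read-out does not separate fluoro from methyl at this place. Nothing measured here gives a cause for this step.

The compounds shown leave open whether an amine or a carboxylic acid on this carbon would move the number beyond the scatter. They also leave open whether the same exchange reads alike without the trifluoromethyl.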